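A few compounds are considered here, and "the series" means these few. Any claim that something is new, unique, unknown or untested is made for them only; others in the source may bear on it.

Compound 3 `CCCCC1CC(=O)N(c2ccccc2C(=O)OCC2CCCN(CCCc3ccccc3)C2)C1=O` gives the lowest of the three numbers in a functional assay with Neuronal acetylcholine receptor; alpha3/beta4 (Homo sapiens) as the target (a higher number here means a weaker inhibitor, a lower number a stronger inhibitor), at 1500 nM. Compound 1 `CC1C(=O)N(c2ccccc2C(=O)OCC2CCCN(CCCc3ccccc3)C2)C(=O)C1C` gives 6000 nM and compound 2 `CCC1CC(=O)N(c2ccccc2C(=O)OCC2CCCN(CCCc3ccccc3)C2)C1=O` gives 4500 nM; the steps of a 4.0-fold lower number from compound 1 to compound 3 (0.60 log units; beyond the scatter) and a 3.0-fold lower number from compound 2 to compound 3 (0.48 log units; beyond the scatter) set compound 3 apart, while the step of a 1.3-fold lower number from compound 1 to compound 2 (0.12 log units; within the scatter) does not separate the other two. Compound 4 `CCCCCCCCC1CC(=O)N(c2ccccc2C(=O)OCC2CCCN(CCCc3ccccc3)C2)C1=O` differs from compound 3 by butyl in place of hydrogen on a saturated chain carbon, four bonds along the chain from a saturated ring carbon. The measured step that bears on this is the chain lengthening from compound 2 to compound 3, which lowered the number modestly. A further lengthening of the same chain is therefore expected to lower the number again, though the gain may flatten. The expected step is a 1.9-fold lower number from compound 3 to compound 4 (0.27 log units; within the scatter). Compound 4 is estimated at 800 nM, with a range of 300 nM to 2500 nM.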

Compound 4, half-maximal inhibitory concentration: 1300 nM
The estimate for compound 4 lay 1.6-fold (0.21 log units) below the measured number; measured number inside the range.
By their numbers in this assay, from the lowest: compounds 4 and 3 (each within the scatter of the next); then compounds 2 and 1 (each within the scatter of the next).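

In this assay, butyl in place of hydrogen gives a 1.2-fold lower number from compound 3 to compound 4 (0.06 log units; within the scatter), so at this position the further lengthening adds nothing that can be told from scatter, unlike the earlier step from ethyl-bearing compound 2 to compound 3. The longer chain still holds the modest difference from the short-chain end, with a 3.5-fold lower number from compound 2 to compound 4 (0.54 log units; beyond the scatter). No supporting evidence is available to account for this levelling. The compounds shown leave open whether a chain of intermediate length would differ from these. They also leave open whether a chain ending in an amine or a carboxylic acid would be tolerated at this position.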